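A Small Chain Change on the Carbamate Ester

The compounds below may be only part of what the source reports. "The series", "measured", "known", "first", "only" and "open" are said of these compounds alone.

Compound 1 `N#C[Se]c1ccc(NC(=O)OCc2ccc([N+](=O)[O-])cc2)cc1`: 71900 nM
Compound 2 `CC(C)COC(=O)Nc1ccc([Se][Se]c2ccc(NC(=O)OCC(C)C)cc2)cc1`: 77400 nM
Compound 3 `C=CCOC(=O)Nc1ccc([Se]C#N)cc1`: 72800 nM

All three measured compounds were tested in a functional assay on HT-29 cells (Homo sapiens) for cytotoxicity, read by MTT assay, with a stated time of 72 h; on this read-out lower numbers stand for higher toxicity in this test and higher numbers for lower toxicity in this test. Their numbers sit close together: compound 3 holds the second highest of the three, its nearest neighbour is compound 1 and its furthest is compound 2, and both gaps fall within the usual scatter of repeated measurements, so no order among them can be read from these data. Whatever the ester end of the carbamate carries here, the cells respond much alike.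

Compound 4 `CCCOC(=O)Nc1ccc([Se]C#N)cc1` has not been measured. It differs from compound 3 in one place: ethyl in place of vinyl on a saturated chain carbon bound to an oxygen next to a carbonyl group. Cut one bond further out, the change reads allyl to propyl, or allyloxy to propoxy.

Within the data shown here, no step between two measured compounds is known that isolates this kind of change. Since every change so far at this ester end left the numbers in this assay within the scatter, the step from compound 3 to compound 4 is expected to be small, with no direction beyond the scatter: a 1.0-fold higher number from compound 3 to compound 4 (0.00 log units; within the scatter). Compound 4 is therefore estimated to give 73000 nM in this assay, expected to lie between 40000 nM and 135000 nM.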

Compound 4, concentration lethal to 50% of the cells: 75400 nM
The estimate for compound 4 lay 1.0-fold (0.01 log units) below the measured number, and the stated range covers the measured number.
By their numbers in this assay, from the lowest: compounds 1, 3, 4 and 2 (each within the scatter of the next).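

Ethyl in place of vinyl on a saturated chain carbon bound to an oxygen next to a carbonyl group gives a 1.0-fold higher number from compound 3 to compound 4 (0.02 log units; within the scatter) in this assay. Among these compounds, this is the first direct one-place comparison at this position, and it shows that losing the double bond from this chain, with the count of heavy atoms unchanged, leaves the number within the scatter. Nothing available explains why the cells respond so much alike to these two chains.

The compounds shown leave open whether a group of a different kind at this end of the carbamate, such as an amine or a carboxylic acid, would move the number beyond the scatter. They also leave open whether a much longer chain in this place would do so.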